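A few compounds are considered here, and "the series" means these few. Any claim that something is new, unique, unknown or untested is made for them only; others in the source may bear on it.

Compound 1 `CSc1nccc2c1ncn2C1O[C@H](CO)[C@@H](O)[C@H]1O` was tested in a functional assay on EL4 cells (Mus musculus) for inhibition, tested at 100 uM; a higher number here means more inhibition at the concentration tested (going by the name of the read-out), a lower number less inhibition. In this assay compound 1 gives < 5%, which is a limit of the assay rather than a number. Two further compounds sit alongside it. Compound 2 `[O-][n+]1ccc2[nH]cnc2c1` gives 5% in this assay. Compound 3 `CNc1[nH]ccc2ncnc1-2` gives < 5% in this assay, again a limit of the assay and not a number. Compound 1 thus stands where most of the measured compounds stand, at the limit of < 5% in this assay, at which 2 of the 3 values shown sit, and none of the three shows inhibition beyond the scatter.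

Compound 4 `CNc1nccc2c1ncn2C1O[C@H](CO)[C@@H](O)[C@H]1O` has not been measured. It differs from compound 1 in one place: methylamino in place of methylsulfanyl on an aromatic carbon. The change is a methylamino in place of a methylsulfanyl on an aromatic carbon, next to the ring nitrogen, ortho to a fused ring and meta to a fused ring. For the measured compounds named here, no measured pair shows what such a change does here, so the expectation rests on compound 1 alone. In this assay the expected step is a number no lower from compound 1 to compound 4 (the limit leaves the size open), none beyond the scatter. Compound 4 is therefore expected to give about 5% in this assay, within 0% to 15%, most likely reported again only as a limit of the assay.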

Compound 4, a percentage reported as inhibition, at one concentration (the size of the read-out at that concentration, not a potency): 11%
Compound 4: the middle estimate sits 6 percentage points below what was measured; measured number inside the range.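

Placing methylamino instead of methylsulfanyl on this aromatic carbon, next to the ring nitrogen, gives a reading that is a number and not a limit: in this assay compound 4 gives 11%. As far as these compounds go, the change is read as a number at least 6 percentage points higher from compound 1 to compound 4 (that floor lies within the scatter), so it cannot be said to raise inhibition, and the true size of the step stays unknown. The value of compound 1 is a limit of the assay, and such limits remain common in this small set: the limit of < 5% in this assay, at which 2 of the 4 values shown sit.

From the compounds shown here alone, what a plain amine, a methoxy group or a longer chain such as ethylamino would do at this position remains open. Going by these compounds, it is also open whether any group here can lift inhibition beyond the usual scatter of this assay.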